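The source may report more compounds than this note shows. Statements on the series, on what has been measured and on what is new or still open speak of the compounds shown alone.

Working notes on the series. The shared core is held constant, and compound 1 `C[C@@H](NC(=O)c1ccc(C#Cc2ccccc2F)cn1)C(C)(C)O`, compound 2 `C[C@@H](NC(=O)c1ccc(C#Cc2ccc(F)cc2)cn1)C(C)(C)O` and compound 3 `C[C@@H](NC(=O)c1ccc(C#Cc2ccc(F)cc2F)cn1)C(C)(C)O` differ only in the aryl ring on the triple-bonded carbon. In a functional assay on HEK293 cells for positive allosteric modulation of metabotropic glutamate receptor 5 (Rattus norvegicus), read by fluorescence and calcium flux (on this read-out higher numbers stand for larger maximal responses and lower numbers for smaller maximal responses), compound 1 gives 60%, compound 2 gives 66.2% and compound 3 gives 61.2%. Compound 3 stands second highest of the three numbers, nearest to compound 1 and furthest from compound 2, and both gaps sit within the scatter. The aryl changes seen so far moved the read-out little: a number 6.2 percentage points higher from compound 1 to compound 2 (within the scatter), a number 1.2 percentage points higher from compound 1 to compound 3 (within the scatter) and a number 5 percentage points lower from compound 2 to compound 3 (within the scatter).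

Compound 4 `Cc1ccccc1C#Cc1ccc(C(=O)N[C@H](C)C(C)(C)O)nc1` has not been measured in this assay. Its change from compound 3 is 2-methylphenyl in place of 2,4-difluorophenyl on a triple-bonded carbon. Among the compounds with values here, no measured step exchanges fluorine for a methyl group on this ring, so the steps that bear on it are only those varying the aryl group, each within the scatter. On that basis no step beyond the scatter is expected in this assay, in either direction, and the step estimated is a number 0.8 percentage points higher from compound 3 to compound 4 (within the scatter). Compound 4 is expected to give about 62% in this assay, with an estimated range of 48% to 76%.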

Compound 4, largest response reached (reported as efficacy), in percent of the reference or control that the assay uses: 59.9%
Compound 4: the middle estimate sits 2.1 percentage points above what was measured, within the range that was stated.
By their numbers in this assay, from the lowest: compounds 4, 1, 3 and 2 (each within the scatter of the next).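

Within the data shown here, compound 4 is the first aryl group to carry no fluorine, and in this assay the exchange of fluoro for methyl on an aromatic carbon is a number 0.1 percentage points lower from compound 1 to compound 4 (within the scatter) and so does not separate the two compounds. The wider exchanges read the same way, with 2-methylphenyl in place of 2,4-difluorophenyl giving a number 1.3 percentage points lower from compound 3 to compound 4 (within the scatter) and 2-methylphenyl in place of 4-fluorophenyl giving a number 6.3 percentage points lower from compound 2 to compound 4 (within the scatter) in this read-out. On a triple-bonded carbon, then, a fluorine on the aryl ring is not required for a maximal response of this size in these four compounds, although nothing available explains why the response tolerates this exchange.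

The aryl groups shown carry only fluoro or methyl, so it remains open whether an amine, a carboxylic acid or a methoxy group on the same ring would also stay within the scatter. Also open, going by these compounds, is whether a longer chain in place of the methyl group, or a ring containing nitrogen in place of the phenyl ring, would keep the response in this assay as it stands here.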